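This account rests on a few compounds, and the source may have more. Where it says the series, first, only, none or still open, it means among the compounds named here.

Values in an assay on isolated protein for activation of Nicotinamide phosphoribosyltransferase (Homo sapiens) (a lower number here means that less compound is needed, a higher number that more compound is needed for the effect), for the three measured compounds:

Compound 1, `CCOC(=O)c1ccc(NC(=O)NCc2cocn2)cc1`: 27600 nM
Compound 2, `CCOC(=O)c1ccc(NC(=O)NCc2c[nH]nn2)cc1`: 7750 nM
Compound 3, `CCOC(=O)c1ccc(NC(=O)NCc2cc[nH]n2)cc1`: 69000 nM

All three share the same core and differ only in the five-membered aromatic ring hung on a saturated chain carbon bound to an amide-type nitrogen. Compound 3 stands highest of the three numbers, which in this assay means it needs the most compound: the step of a 2.5-fold higher number from compound 1 to compound 3 (0.40 log units; beyond the scatter) and the step of an 8.9-fold higher number from compound 2 to compound 3 (0.95 log units; beyond the scatter) both run toward higher numbers, and both lie beyond the scatter. The step of a 3.6-fold lower number from compound 1 to compound 2 (0.55 log units; beyond the scatter) shows how far the ring choice alone can move the result.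

Compound 4, `CCOC(=O)c1ccc(NC(=O)NCc2ccnnc2)cc1`, is the next compound, not yet measured. It differs from compound 3 by pyridazin-4-yl in place of 1H-pyrazol-3-yl on a saturated chain carbon bound to an amide-type nitrogen. Among the compounds with values here, no measured step swaps a five-membered ring for a six-membered one, so the bearing of the known steps is indirect: every other ring tried at this position gave a lower number than compound 3, so compound 3 is a weak point of departure and a new ring has room to improve on it. The expectation for compound 4 is therefore a modest move toward a lower number, a 2.3-fold lower number from compound 3 to compound 4 (0.36 log units; beyond the scatter), with wide uncertainty. Compound 4 is estimated at 30000 nM, within a range of 8000 nM to 120000 nM.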

Compound 4, half-maximal effective concentration: > 100000 nM
Compound 4 was reported as a limit; the forecaster's own chance of this, stated with the estimate: 15%; middle value at least 3.3-fold (0.52 log units) from the limit.
By their numbers in this assay, from the lowest: compound 2; then compound 1; then compound 3. At a limit, above all of these: compound 4.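

In this assay, compound 4 is reported only as a limit, not as a number: the limit of > 100000 nM in this assay, at which 1 of the 4 values shown sits.

Pyridazin-4-yl, the only six-membered ring shown at this position, gives an at least 1.4-fold higher number from compound 3 to compound 4 (0.16 log units; that floor lies within the scatter), so this result does not separate compound 4 from compound 3, while an at least 3.6-fold higher number from compound 1 to compound 4 (0.55 log units; beyond the scatter) and an at least 12-fold higher number from compound 2 to compound 4 (1.11 log units; beyond the scatter) do place it clearly on the higher side of the other two compounds. Within the data shown here, what this adds to the earlier comparisons among five-membered rings is that moving to a six-membered ring with two nitrogens brought no lower number, and the 1H-1,2,3-triazol-4-yl group of compound 2 keeps the lowest number of the four.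

The limit leaves open how much compound compound 4 would actually need, and a single example cannot show whether the six-membered ring itself or the way its two nitrogens are arranged matters more. Also open, from the compounds shown here alone, is how the result would change with a carboxylic acid or an amine on the ring, or with a longer chain on the amide-type nitrogen.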